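A few compounds are considered here, and "the series" means these few. Any claim that something is new, unique, unknown or untested is made for them only; others in the source may bear on it.

Within the data shown here, only two compounds have been measured so far. In a functional assay on MCF7 cells (Homo sapiens) for inhibition, read by sulforhodamine B assay, with a stated time of 48 h, tested at 50 uM (a lower number here means less inhibition of growth, a higher number more inhibition of growth at the concentration tested), compound 1 `COc1ccc([C@@H]2C/C(=N/OCc3cn(-c4ccc(O)cc4)nn3)c3cc(CC=C(C)C)c(OC)cc3O2)cc1` gives 63% and compound 2 `COc1ccc([C@@H]2C/C(=N/O)c3cc(CC=C(C)C)c(OC)cc3O2)cc1` gives 63%. Among the measured compounds shown here, compound 2 therefore stands level with the only other compound measured, within the scatter of repeated readings.

The next compound, compound 3 `C#CCO/N=C1/C[C@@H](c2ccc(OC)cc2)Oc2cc(OC)c(CC=C(C)C)cc21`, differs from compound 2 in one place: propargyl in place of hydrogen on an oxygen. A propargyl takes the place of a hydrogen on an oxygen, so that hydroxy becomes propargyloxy. For the measured compounds named here, no measured step shows what this change does. Going by the values given here, with compound 1 at 63% as the only other reading, no step beyond the scatter is expected in this assay, in either direction. The expected change is small, a number 3 percentage points lower from compound 2 to compound 3 (within the scatter). For compound 3 the estimated value is 60%, with a range of 45% to 75%.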

Compound 3, percent growth inhibition at one concentration: 61%
For compound 3 the middle estimate is 1 percentage points below the measured one; low and high end bracket the measured number.
By their numbers in this assay, from the lowest: compounds 3, 1 and 2 (each within the scatter of the next).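

In this assay the step is a number 2 percentage points lower from compound 2 to compound 3 (within the scatter), so the hydrogen on this oxygen can give way to propargyl without a shift beyond the scatter. The other comparison, a number 2 percentage points lower from compound 1 to compound 3 (within the scatter), shows that a bare ethynyl and a 1-(4-hydroxyphenyl)-1H-1,2,3-triazol-4-yl at the end of this arm also read alike, so this position has so far accepted a hydrogen, a short propargyl and a much larger arm with no visible effect on the reading. Nothing available explains this lack of effect.

As far as these compounds go, it remains open whether a carboxylic acid or an amine at the end of a longer chain on this oxygen would separate from these three compounds. A single tested concentration also leaves open whether their full dose responses match.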